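Dimethylamino in Place of Methylsulfanyl: Expected Inhibition

The source may hold more compounds than are shown below. What is called first, only, known or untested is meant among the compounds shown, and "the series" means these compounds.

Measured compounds:
compound 1, `CSc1nccc2c1ncn2C1O[C@H](CO)[C@@H](O)[C@H]1O`, gives 24%
compound 2, `[O-][n+]1ccc2[nH]cnc2c1`, gives 3%

Of the compounds shown here, two have been tested in a functional assay (Homo sapiens) for inhibition of Nucleic Acid, tested at 100 uM; a higher number here means more inhibition at the concentration tested (going by the name of the read-out), a lower number less inhibition. Compound 1 reaches 24% in this assay, the highest of the two numbers, while compound 2 gives 3%, a gap that lies beyond the usual scatter. Compound 1 and compound 2 differ in several places at once, so no single structural step can be read from them.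

Compound 3, `CN(C)c1nccc2c1ncn2C1O[C@H](CO)[C@@H](O)[C@H]1O`, has not been measured. It differs from compound 1 in one place: dimethylamino in place of methylsulfanyl on an aromatic carbon. Among the compounds with values here, both groups carry one hydrogen-bond acceptor and neither carries a charge, and with no measured single-change step to lean on, only a modest step is expected from compound 1 to compound 3, most likely none beyond the scatter, estimated as a number 6 percentage points lower from compound 1 to compound 3 (within the scatter). For compound 3 the expected value in this assay is 18%, with a range from 2% to 40%.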

Compound 3, a percentage reported as inhibition, at one concentration (the size of the read-out at that concentration, not a potency): 0%
The estimate for compound 3 lay 18 percentage points above the measured number, and the stated range ends above it.
By their numbers in this assay, from the lowest: compounds 3 and 2 (each within the scatter of the next); then compound 1.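

Dimethylamino in place of methylsulfanyl on this aromatic carbon, next to the ring nitrogen, is the first change in one place that can be read in this assay: it gives a number 24 percentage points lower from compound 1 to compound 3 (beyond the scatter). The two groups match in having one hydrogen-bond acceptor, no hydrogen-bond donor and no net charge, yet the read-out still separates them, so matching on those counts does not make these groups interchangeable at this position. Nothing measured here explains the difference.

On these data alone, whether the sulfur atom itself matters, or some other difference between the two groups, remains open. A methoxy group, a primary amine or a longer chain such as ethylsulfanyl on the same carbon could help to tell these possibilities apart.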